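Moving the acid on the benzyl arm of compound 3

This account rests on a few compounds, and the source may have more. Where it says the series, first, only, none or still open, it means among the compounds named here.

Of the compounds shown here, three have been tested in a functional assay on HEK293 cells for agonist activity at Bile acid receptor (Homo sapiens); on this read-out lower numbers stand for smaller maximal responses and higher numbers for larger maximal responses. Compound 1, `Cc1cc(OCc2c(-c3c(Cl)cccc3Cl)noc2C(C)C)nc2ccccc12`, gives 40%. Compound 2, `CC(C)c1onc(-c2c(Cl)cccc2Cl)c1COc1ccc(NCc2ccc(C(=O)O)cc2)c(C(F)(F)F)n1`, gives 48%. Compound 3, `CC(C)c1onc(-c2c(Cl)cccc2Cl)c1COc1cnc(N(C)Cc2ccc(C(=O)O)cc2)c(Cl)c1`, gives 70%. Among these three numbers compound 3 stands highest: its result lies above that of compound 2 by a margin beyond the usual scatter, and further still above that of compound 1, again beyond the scatter.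

Compound 4, `CC(C)c1onc(-c2c(Cl)cccc2Cl)c1COc1cnc(N(C)Cc2cccc(C(=O)O)c2)c(Cl)c1`, is built from the same atoms as compound 3, joined differently. The change is 3-carboxyphenyl in place of 4-carboxyphenyl on a saturated chain carbon bound to a nitrogen on an aromatic ring The carboxylic acid is kept, only its position on the phenyl ring of the benzyl arm moves.

Among the measured compounds shown here, no pair of measured compounds differs in exactly one place, so no measured step shows what such a shift of an acid does here. The expectation can rest only on the fact that compound 3 already gives the largest response of the three, and on the modest nature of the rearrangement. A small loss is expected, not clearly beyond the scatter, so the step from compound 3 to compound 4 is estimated at a number 15 percentage points lower from compound 3 to compound 4 (beyond the scatter). In this assay compound 4 is therefore expected to give about 55%, most likely between 30% and 80%.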

Compound 4, largest response reached (reported as efficacy), in percent of the reference or control that the assay uses: 42%
The estimate for compound 4 lay 13 percentage points above the measured number, and the stated range covers the measured number.
By their numbers in this assay, from the lowest: compounds 1, 4 and 2 (each within the scatter of the next); then compound 3.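

In this assay, this is the first change in a single place among the compounds shown, and moving the acid gives a number 28 percentage points lower from compound 3 to compound 4 (beyond the scatter). Compounds 3 and 4 are built from the same atoms and both keep the carboxylic acid, so in this pair the response depends on where the acid sits on the phenyl ring and not only on its presence: the 4-carboxyphenyl arm gives the larger maximal response and the 3-carboxyphenyl arm the smaller one. No measurement at hand explains why the response falls with this shift.

One pair cannot show whether the 4-carboxyphenyl arm would keep this edge on another scaffold, such as the shared core with the different ring substituents and the secondary amine link of compound 2. Going by these compounds, it also remains open how the response would change with a tetrazole in place of the carboxylic acid, or with a carboxymethyl group, which sets the acid on a longer chain from the same phenyl ring.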